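This account rests on a few compounds, and the source may have more. Where it says the series, first, only, none or still open, it means among the compounds named here.

Working notes on the series.

Compound 2 `Cc1ccccc1Nc1ccc(C#N)cc1S(=O)(=O)NC(=O)NC(C)C` is the compound under comparison. In a functional assay on HEK293 cells for antagonist activity at thromboxane A2 receptor (Homo sapiens), read by fluorescence and calcium flux (a higher number here means a weaker inhibitor, a lower number a stronger inhibitor), compound 2 gives 7240 nM, which is the highest of the two numbers recorded so far. Going by the values given here, the nearest neighbour by number is compound 1 `CCCCCNC(=O)NS(=O)(=O)c1cc(C#N)ccc1Oc1ccccc1C`, which in this assay gives 2240 nM; the gap between the two values lies beyond the scatter, but the two compounds differ in more than one place, so no single step is drawn between them.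

Compound 3 `CCCCCNC(=O)NS(=O)(=O)c1cc(C#N)ccc1Nc1ccccc1C` has not yet been measured. The change from compound 2 to compound 3 is pentyl in place of isopropyl on an amide-type nitrogen. Compound 1 also carries the pentyl chain at that nitrogen, though with a different linker to the methyl-substituted ring, so its value is only a loose pointer.

A step toward a lower number is expected for the change from compound 2 to compound 3 in this assay, of size a 2.3-fold lower number from compound 2 to compound 3 (0.35 log units; beyond the scatter), because compound 1 with the pentyl chain gives 2240 nM. Compound 3 is therefore estimated at 3200 nM in this assay, with a range from 1000 nM to 10000 nM.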

Compound 3, half-maximal inhibitory concentration: 3190 nM
Beside the measured number, compound 3's estimate is 1.0-fold (0.00 log units) above it; measured number inside the range.
By their numbers in this assay, from the lowest: compounds 1 and 3 (each within the scatter of the next); then compound 2.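

In this assay, the series now has its first step read at the amide-type nitrogen with everything else held: pentyl in place of isopropyl gives a 2.3-fold lower number from compound 2 to compound 3 (0.36 log units; beyond the scatter), a modest move toward stronger inhibition. The second step shows that, with the pentyl chain in place, (2-methylphenyl)amino in place of 2-methylphenoxy on an aromatic carbon gives a 1.4-fold higher number from compound 1 to compound 3 (0.15 log units; within the scatter), so this pair does not separate the two groups in this assay, and the difference between compound 1 and compound 2 can be read as lying mainly at the chain rather than at that aromatic carbon. Nothing at hand bears on why either step has the size it has.

Two chains do not show whether the number keeps falling with length, or whether a shorter chain such as ethyl, a longer one such as octyl, a ring such as cyclohexyl or a chain ending in an amine would follow the same direction at this nitrogen. Going by these compounds, it also remains open whether the isopropyl to pentyl step carries over to the shared core with 2-methylphenoxy, or with a ring that lacks the methyl group.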